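The source may hold more compounds than are shown below. What is called first, only, known or untested is meant among the compounds shown, and "the series" means these compounds.

Of the compounds shown here, two have been measured so far in a functional assay on U-87MG ATCC cells (Homo sapiens) for inhibition, read by trypan blue exclusion, with a stated time of 72 h; on this read-out higher numbers stand for weaker inhibition of growth and lower numbers for stronger inhibition of growth. Compound 1 (`Cn1c(=O)c(S(=O)(=O)c2ccc(OC(=O)CCCCC3SCC4NC(=O)NC43)cc2)cc2cnc(Nc3ccc4[nH]ccc4c3)nc21`) gives 1000 nM and compound 2 (`Cn1c(=O)c(S(=O)(=O)c2ccc(F)cc2)cc2cnc(Nc3ccc4[nH]ccc4c3)nc21`) gives 400 nM as the lower of the two numbers, with a gap beyond the usual scatter of repeats. Compound 3 (`Cn1c(=O)c(S(=O)(=O)c2ccc(O)cc2)cc2cnc(Nc3ccc4[nH]ccc4c3)nc21`) is still unmeasured. It keeps the core of compound 2 and changes one group, with hydroxy in place of fluoro on an aromatic carbon, para to a large group (hydroxy in place of fluoro on an aromatic carbon). Among the compounds with values here, no measured pair shows this swap directly. Within the data shown here, the only hint is that compound 1, with a far bigger group at that same place, reads 1000 nM and so remains in the same broad range. A small rise in the number, perhaps none beyond the scatter, is therefore expected in this assay. The estimated size is a 1.3-fold higher number from compound 2 to compound 3 (0.10 log units; within the scatter) in all. Compound 3 is expected at 500 nM with a range of 170 nM to 1500 nM around that estimate.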

Compound 3, concentration for 50% growth inhibition: 1000 nM
Beside the measured number, compound 3's estimate is 2.0-fold (0.30 log units) below it; the range from low to high includes it.
By their numbers in this assay, from the lowest: compound 2; then compounds 1 and 3 (each within the scatter of the next).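

In this assay, within the data shown here, the swap of fluoro for hydroxy on this aromatic carbon gives the first direct reading of a change at this position: a 2.5-fold higher number from compound 2 to compound 3 (0.40 log units; beyond the scatter). A change of one heavy atom is thus enough to move the number past the usual scatter, although the step is modest. Compound 3 gives 1000 nM and compound 1 gives 1000 nM, the same printed number, so on this read-out the small hydroxy and the much larger group of compound 1 on that carbon cannot be told apart.

Nothing shown here gives a reason for this step. As far as these compounds go, whether an amine, a methoxy group or a chlorine on the same carbon would read nearer compound 2 or nearer compound 3 remains open.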